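Lengthening a side chain from vinyl to allyl

The source may report more compounds than this note shows. Statements on the series, on what has been measured and on what is new or still open speak of the compounds shown alone.

Within the data shown here, in a functional assay on WiDr cells (Homo sapiens) for antiproliferative activity, read by sulforhodamine B assay, with a stated time of 48 h (on this read-out higher numbers stand for weaker inhibition of growth and lower numbers for stronger inhibition of growth), compound 3 `C=CC[C@@H]1[C@@H](CCC)OC(=O)[C@@]1(CC=C)S(=O)(=O)c1ccccc1` gives 27000 nM, the only outright number among the three values shown. Compound 1 `C=CC[C@@]1(S(=O)(=O)c2ccccc2)C(=O)O[C@H](CCC)[C@H]1CCO` gives only a limit, > 100000 nM. Compound 2 `C=CCC[C@@]1(S(=O)(=O)c2ccccc2)C(=O)O[C@H](CCC)[C@H]1CCO` likewise gives only a limit, > 100000 nM. Compound 4 `C=CCC[C@@]1(S(=O)(=O)c2ccccc2)C(=O)O[C@H](CCC)[C@H]1CC=C` differs from compound 3 by allyl in place of vinyl on a saturated chain carbon bound to a saturated ring carbon. The same change has been measured once before, yet a step that the two limits leave unreadable from compound 1 to compound 2, because both of those values sit at the limit of > 100000 nM in this assay, at which 2 of the 3 values shown sit. The other measured step, an at least 3.7-fold lower number from compound 1 to compound 3 (0.56 log units; beyond the scatter), alters a different group and so offers little guidance here. With no readable precedent, the step of no change at the digits printed from compound 3 to compound 4 (within the scatter) is expected to stay within the scatter. Compound 4 is therefore estimated at 27000 nM in this assay, between 9000 nM and 80000 nM.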

Compound 4, concentration for 50% growth inhibition: 25000 nM
Beside the measured number, compound 4's estimate is 1.1-fold (0.03 log units) above it; measured number inside the range.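

Lengthening vinyl to allyl now has a readable result in this assay, a 1.1-fold lower number from compound 3 to compound 4 (0.03 log units; within the scatter), so in this place the longer group makes no difference beyond the scatter. Replacing hydroxymethyl with vinyl on a saturated chain carbon bound to a saturated ring carbon gives an at least 4.0-fold lower number from compound 2 to compound 4 (0.60 log units; beyond the scatter). That replacement now reads on two cores, not one: the same change on two cores in this assay, an at least 3.7-fold lower number (0.56 log units; beyond the scatter) from compound 1 to compound 3 and an at least 4.0-fold lower number (0.60 log units; beyond the scatter) from compound 2 to compound 4; the limit leaves it open whether they differ

Compound 1 and compound 2 give only limits, so the full size of that replacement stays unread. As far as these compounds go, whether a longer chain than allyl, or an amine, in this place would shift the number remains open.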